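The source may report more compounds than this note shows. Statements on the series, on what has been measured and on what is new or still open speak of the compounds shown alone.

In a functional assay on KB cells (nasopharynx, Homo sapiens) for antiproliferative activity (on this read-out lower numbers stand for stronger inhibition and higher numbers for weaker inhibition), compound 1 (`COc1ccc(S(=O)(=O)Nc2cccc3cc[nH]c23)cc1`) gives 0.67 ug/mL, while compound 2 (`COc1ccc(S(=O)(=O)Nc2cccc3c(C#N)c[nH]c23)cc1`) gives 1.4 ug/mL, the higher of the two numbers and so the weaker inhibition. The unmeasured compound 3 (`COc1ccc(S(=O)(=O)Nc2cccc3c(Cl)c[nH]c23)cc1`) differs from compound 2 in one group: chloro in place of cyano on an aromatic carbon, (chloro in place of cyano on an aromatic carbon). For the measured compounds named here, the only measured step at that carbon is modest, a 2.1-fold higher number from compound 1 to compound 2 (0.32 log units; beyond the scatter), with cyano in place of hydrogen. Going by the values given here, no chloro compound has been measured, so this step offers only a scale for a change at this place. A step of similar size is therefore expected in this assay, towards a lower number, and the range allows for no real change. The expected step is a 2.0-fold lower number from compound 2 to compound 3 (0.30 log units; within the scatter). For compound 3 the estimated value is 0.7 ug/mL, with an expected range of 0.25 ug/mL to 1.8 ug/mL.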

Compound 3, half-maximal inhibitory concentration: 0.55 ug/mL
Beside the measured number, compound 3's estimate is 1.3-fold (0.10 log units) above it; the range from low to high includes it.
By their numbers in this assay, from the lowest: compounds 3 and 1 (each within the scatter of the next); then compound 2.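

In this assay, the group on this carbon of the five-membered aromatic ring matters in one direction only: chloro in place of cyano gives a 2.5-fold lower number from compound 2 to compound 3 (0.41 log units; beyond the scatter) and so recovers what cyano had lost. Chloro in place of hydrogen gives a 1.2-fold lower number from compound 1 to compound 3 (0.09 log units; within the scatter) and so leaves compound 3 level with compound 1, which makes cyano the only one of the three groups shown that separates from the others at this carbon, with compound 2 the weaker inhibitor. No measurement is at hand that bears on why cyano and chloro part in this way.

The compounds shown leave open what an amine, a carboxylic acid or a longer chain would do at this carbon. They also leave open whether bromo or methyl would stay with chloro and hydrogen or fall with cyano.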